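Swapping 4-methylcyclohexyl for 4-methoxypiperidin-1-yl: an estimate

A few compounds are considered here, and "the series" means these few. Any claim that something is new, unique, unknown or untested is made for them only; others in the source may bear on it.

Two compounds have been measured in an assay on HEK293 cells for positive allosteric modulation of metabotropic glutamate receptor 5 (Homo sapiens), read by FLIPR; a higher number here means that more compound is needed for the effect, a lower number that less compound is needed:
compound 1 `CC1CCC(C(=O)N2CC(c3nc(-c4cccc(Cl)c4)no3)C2)CC1` gives 1500 nM;
compound 2 `O=C(C1CCC(C(F)(F)F)CC1)N1CC(c2nc(-c3cccc(Cl)c3)no2)C1` gives 1000 nM.

Compound 1 stands highest of the two numbers, its nearest neighbour being compound 2 with a 1.5-fold lower number from compound 1 to compound 2 (0.18 log units; within the scatter). Compound 3 `COC1CCN(C(=O)N2CC(c3nc(-c4cccc(Cl)c4)no3)C2)CC1` differs from compound 1 by 4-methoxypiperidin-1-yl in place of 4-methylcyclohexyl on a carbonyl carbon. Going by the values given here, no measured step bears on this change: the only step seen, trifluoromethyl in place of methyl on a saturated ring carbon, was itself within the scatter and touched a different part of the molecule. No step beyond the scatter is therefore expected in this assay, in either direction. Compound 3 is expected at 1500 nM, within 300 nM to 7500 nM, which means an expected no change at the digits printed from compound 1 to compound 3 (within the scatter).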

Compound 3, half-maximal effective concentration: > 10000 nM
Compound 3: only a limit was reported; the forecaster's own chance of this, stated with the estimate: 15%; middle value at least 6.6-fold (0.82 log units) away from the limit.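

In this assay, going by these compounds alone, the earlier compounds showed only a step within the scatter, whereas this change on the carbonyl carbon gives an at least 6.6-fold higher number from compound 1 to compound 3 (0.82 log units; beyond the scatter) and so shows that the group at this place can matter. As far as these compounds go, compound 3 gives > 10000 nM, which is a limit and not a number, so the full size of the step stays unknown. The reading rests on that limit: the limit of > 10000 nM in this assay, at which 1 of the 3 values shown sits.

The ring nitrogen and the methoxy group enter together, so the compounds shown cannot separate them. From the compounds shown here alone, how a 4-methoxycyclohexyl or an unsubstituted piperidin-1-yl group would read in this assay remains open.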